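The source may hold more compounds than are shown below. What is called first, only, known or untested is meant among the compounds shown, and "the series" means these compounds.

Working notes on the series.

Two members of the series have been measured in an ADME assay (Rattus norvegicus, strain Sprauge-Dawley) for metabolic stability; on this read-out higher numbers stand for a longer-lived compound and lower numbers for a shorter-lived compound. Compound 1 `COC(=O)N(C)c1c(N)nc(-n2nc(Cc3ccccc3F)c3cc(F)ccc32)nc1N` gives 1.5 h in this assay. Compound 2 `COC(=O)N(C)c1c(N)nc(-n2nc(Cc3c(F)ccc(F)c3F)c3ccccc32)nc1N` gives 2.2 h in this assay. Among the measured compounds shown here, the two values lie within the usual scatter of each other, so compound 2 stands at a level that the numbers so far cannot separate from that of compound 1.

The next member is compound 3 `COC(=O)N(C)c1c(N)nc(-n2nc(Cc3c(F)ccc(F)c3F)c3cc(Cl)ccc32)nc1N`, which is not yet measured in this assay. Compound 3 differs from compound 2 in one place: chloro in place of hydrogen on an aromatic carbon. Nothing else in the structure changes.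

For the measured compounds named here, no step between two measured compounds that differ in a single place is available in this assay, so the size of the step from compound 2 to compound 3 has to be judged without a reference. On the numbers shown, the expected outcome is a step that stays within the scatter, in either direction or none at all; the expected step is a 1.1-fold higher number from compound 2 to compound 3 (0.04 log units; within the scatter). Compound 3 is therefore estimated to give 2.4 h in this assay, with a range from 1.1 h to 5 h.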

Compound 3, half-life: 3.6 h
The estimate for compound 3 lay 1.5-fold (0.18 log units) below the measured number, and the stated range covers the measured number.
By their numbers in this assay, from the lowest: compounds 1, 2 and 3 (each within the scatter of the next, the first and the last beyond it).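

In this assay, among the compounds shown here, chloro in place of hydrogen on an aromatic carbon, meta to a fused ring and para to a fused ring, gives a 1.6-fold higher number from compound 2 to compound 3 (0.21 log units; within the scatter) and is the first single-place step available. It shows that this position of the shared core can carry a chloro while the half-life stays within the scatter of the hydrogen compound, so compound 2 and compound 3 cannot be separated on this read-out. No measurement shown bears on what lies behind this step.

A single step at one position leaves open whether the half-life would stay within the scatter with other groups there, such as a methoxy group, an amine or a carboxylic acid. It also leaves open whether chloro on the other aromatic carbons of this ring, or on a compound with a different substitution pattern on the fluorinated benzyl group, would give a step of similar size.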